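Compound 3 to compound 4: an aryl swap on the sulfonamide

A few compounds are considered here, and "the series" means these few. Any claim that something is new, unique, unknown or untested is made for them only; others in the source may bear on it.

Going by the values given here, in a functional assay on MCF7 cells (Homo sapiens) for antiproliferative activity, read by sulforhodamine B assay, with a stated time of 48 h (on this read-out higher numbers stand for weaker inhibition and lower numbers for stronger inhibition), compound 3 (`Cc1ccc(NS(=O)(=O)c2ccc(N3CCNC3=O)cc2)cc1C`) gives 230 nM and sits within the scatter of compound 1 (`CCc1ccccc1NS(=O)(=O)c1ccc(N2CCNC2=O)cc1`) at 350 nM on the only two numbers available. Compound 2 (`O=C1NCCN1c1ccc(S(=O)(=O)Nc2ccc(C3CCCCC3)cc2)cc1`) returns only a limit, > 1000 nM and no number. Compound 4 (`O=C1NCCN1c1ccc(S(=O)(=O)Nc2ccc(I)cc2)cc1`) carries 4-iodophenyl in place of 3,4-dimethylphenyl on a sulfonamide nitrogen is the whole change. Among the compounds with values here, the one measured step at that nitrogen, a 1.5-fold lower number from compound 1 to compound 3 (0.18 log units; within the scatter) stays within the scatter and gives no grounds for a large move. The expected step, a 1.5-fold higher number from compound 3 to compound 4 (0.18 log units; within the scatter) is therefore estimated to stay within the scatter as well. For compound 4 an estimated 350 nM with a range from 120 nM to 1000 nM is expected here.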

Compound 4, half-maximal inhibitory concentration: 600 nM
For compound 4 the middle estimate is 1.7-fold (0.23 log units) below the measured one, and the stated range covers the measured number.
By their numbers in this assay, from the lowest: compounds 3, 1 and 4 (each within the scatter of the next, the first and the last beyond it). At a limit, above all of these: compound 2.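

In this assay, the aryl group on the sulfonamide nitrogen now gives its first step beyond the scatter: a 2.6-fold higher number from compound 3 to compound 4 (0.42 log units; beyond the scatter). Against the 2-ethylphenyl of compound 1, the same 4-iodophenyl gives a 1.7-fold higher number from compound 1 to compound 4 (0.23 log units; within the scatter), so across compounds 1, 3 and 4 this position shows only modest movement. With iodo in place of cyclohexyl the step reads an at least 1.6-fold lower number from compound 2 to compound 4 (0.22 log units; that floor lies within the scatter), and compound 2 gives a limit, not a number: the limit of > 1000 nM in this assay, at which 1 of the 4 values shown sits.

From the compounds shown here alone, how an amine or a carboxylic acid on this aryl group would read remains open, as does chloro in place of iodo.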